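The source may hold more compounds than are shown below. What is called first, only, known or untested is meant among the compounds shown, and "the series" means these compounds.

In a functional assay on DU-145 cells (Homo sapiens) for cytotoxicity, read by MTT assay, with a stated time of 48 h (a higher number here means a weaker inhibitor, a lower number a stronger inhibitor), compound 3 `CCn1c(/C=C2/C(=O)Nc3ccc(Br)cc32)nc2ccccc21` gives 45800 nM, the higher of the two numbers measured, while compound 1 `CC(C)n1c(/C=C2/C(=O)Nc3ccc(Br)cc32)nc2ccccc21` gives 7500 nM. For compound 2 `Cn1c(/C=C2/C(=O)Nc3ccc([N+](=O)[O-])cc32)nc2ccccc21` the reading is only a limit, > 50000 nM. Compound 4 `Cn1c(/C=C2/C(=O)Nc3ccc(Br)cc32)nc2ccccc21` departs from compound 3 by hydrogen in place of methyl on a saturated chain carbon bound to an aromatic nitrogen, which reads as ethyl to methyl. One measured step is of the same kind, hydrogen in place of methyl on a saturated chain carbon bound to an aromatic nitrogen, and it is modest: a 6.1-fold higher number from compound 1 to compound 3 (0.79 log units; beyond the scatter). On that single step, a smaller move toward a higher number is expected in this assay, and the expected step is a 1.3-fold higher number from compound 3 to compound 4 (0.12 log units; within the scatter). Compound 4 is estimated at 60000 nM, with an expected range of 15000 nM to 200000 nM.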

Compound 4, half-maximal inhibitory concentration: 39600 nM
Compound 4: the middle estimate sits 1.5-fold (0.18 log units) above what was measured; the range from low to high includes it.
By their numbers in this assay, from the lowest: compound 1; then compounds 4 and 3 (each within the scatter of the next). At a limit, above all of these: compound 2.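

Hydrogen in place of methyl on a saturated chain carbon bound to an aromatic nitrogen, which reads as ethyl to methyl, gives a 1.2-fold lower number from compound 3 to compound 4 (0.06 log units; within the scatter) so the two straight chains cannot be told apart, which places the separation at the isopropyl group alone. Methyl in place of isopropyl gives a 5.3-fold higher number from compound 1 to compound 4 (0.72 log units; beyond the scatter) and so matches the ethyl comparison in direction and rough size. Bromo in place of nitro on an aromatic carbon gives an at least 1.2-fold lower number from compound 2 to compound 4 (0.10 log units; that floor lies within the scatter) but this step cannot be read further, the value of compound 2 being a limit: (the limit of > 50000 nM in this assay, at which 1 of the 4 values shown sits).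

Open, from the compounds shown here alone, is whether a longer chain such as butyl, or a cyclopropyl or tert-butyl group, on that nitrogen would follow isopropyl or the straight chains.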